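Extending a Side Chain on an Enediyne-Ester Scaffold

The source may report more compounds than this note shows. Statements on the series, on what has been measured and on what is new or still open speak of the compounds shown alone.

Three compounds have numbers in a functional assay on HBL-100 cells (Homo sapiens) for antiproliferative activity, read by sulforhodamine B assay, with a stated time of 48 h; on this read-out lower numbers stand for stronger inhibition of growth and higher numbers for weaker inhibition of growth. Compound 1 `CC1CCC(C(C)C)C(OC(=O)C#CC(O/C=C/C(=O)OC2CC(C)CCC2C(C)C)C(C)C)C1` reaches only a limit of the assay, > 100000 nM, and gives no number. Compound 2 `COC(=O)C#CC(O/C=C/C(=O)OC)C(C)c1ccccc1` gives 490 nM. Compound 3 `CCC(C#CC(=O)OC)O/C=C/C(=O)OC` gives 320 nM, the lowest of the two numbers shown, though its only neighbour, compound 2, sits within the usual scatter of it. For the measured compounds named here, the one measured step that bears on the new change is a 1.5-fold lower number from compound 2 to compound 3 (0.19 log units; within the scatter); swapping a phenyl for a hydrogen on that chain carbon moved the number by less than repeat measurements do.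

Compound 4 `CCCC(C#CC(=O)OC)O/C=C/C(=O)OC` differs from compound 3 by methyl in place of hydrogen on a saturated chain carbon, three bonds along the chain from an oxygen on an unsaturated carbon and a triple-bonded carbon. This is a smaller change than the phenyl-to-hydrogen exchange, on the same carbon of the saturated chain, so no step beyond the scatter is expected; compound 4 is estimated to land at about a 1.1-fold lower number from compound 3 to compound 4 (0.03 log units; within the scatter), giving an estimated value of 300 nM, with a range from 120 nM to 800 nM.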

Compound 4, concentration for 50% growth inhibition: 270 nM
The estimate for compound 4 lay 1.1-fold (0.05 log units) above the measured number; measured number inside the range.
By their numbers in this assay, from the lowest: compounds 4, 3 and 2 (each within the scatter of the next). At a limit, above all of these: compound 1.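

In this assay, turning the ethyl of compound 3 into the propyl of compound 4 gives a 1.2-fold lower number from compound 3 to compound 4 (0.07 log units; within the scatter). For the compounds shown here, until now, the only measured step on this side chain was the exchange of a phenyl for a hydrogen, so this is the first look at what a single added methyl does, and it too stays within the scatter, which means the two compounds cannot be told apart here. Nothing measured in this set speaks to why a methyl at this place leaves the number within the scatter.

The compounds shown leave open whether a chain longer than propyl would give a step beyond the scatter. They also leave open what an amine or a carboxylic acid at the end of this chain would do.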